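A few compounds are considered here, and "the series" means these few. Any claim that something is new, unique, unknown or untested is made for them only; others in the source may bear on it.

Measured in a functional assay on A549 cells (Homo sapiens) for antiproliferative activity, read by CCK-8 assay, with a stated time of 72 h; a higher number here means a weaker inhibitor, a lower number a stronger inhibitor:
- Compound 1 `C/C(=N\O)c1ccc(OCc2ccc(C(=O)NO)cc2)cc1`: 8930 nM
- Compound 2 `Nc1ccccc1NC(=O)c1ccc(COc2ccc(Br)cc2)cc1`: 24400 nM
- Compound 3 `Nc1ccccc1NC(=O)c1ccc(COc2ccc(Cl)cc2)cc1`: > 32000 nM, a limit of the assay and not a number

Compound 3 has no exact place on this scale, only a limit: the limit of > 32000 nM in this assay, at which 1 of the 3 values shown sits. Compound 4 `CCc1ccc(OCc2ccc(C(=O)Nc3ccccc3N)cc2)cc1` differs from compound 3 in one group: ethyl in place of chloro on an aromatic carbon.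

Among the measured compounds shown here, only one measured step changes this same place, and it is an at least 1.3-fold higher number from compound 2 to compound 3 (0.11 log units; that floor lies within the scatter). It swaps one halogen for another, so it is only a loose guide to a swap for ethyl. For the measured compounds named here, compound 1 differs from the others in more than one place and offers no matching step. Going by the values given here, compound 2, at 24400 nM, gives the only actual number for this shared core, so the expectation is anchored there. No step beyond the scatter is expected in this assay, and compound 4 may also return only a limit. The expected size of the change is an at least 1.2-fold lower number from compound 3 to compound 4 (0.09 log units; that floor lies within the scatter), and it has no firm starting point. For compound 4 the estimate is 26000 nM, with an expected range of 11000 nM to 50000 nM.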

Compound 4, half-maximal inhibitory concentration: 6420 nM
Beside the measured number, compound 4's estimate is 4.0-fold (0.61 log units) above it; the whole stated range lies above it.
By their numbers in this assay, from the lowest: compounds 4 and 1 (each within the scatter of the next); then compound 2. At a limit, above all of these: compound 3.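

In this assay, among the compounds shown here, replacing the halogen on this aromatic carbon, para to a large group, with ethyl gives the first change here that has an exact number at both ends and clearly exceeds the scatter: a 3.8-fold lower number from compound 2 to compound 4 (0.58 log units; beyond the scatter). The other new step, an at least 4.9-fold lower number from compound 3 to compound 4 (0.69 log units; beyond the scatter), gives only a floor for the true size of the change, because its starting value is a limit of the assay and not a number: the limit of > 32000 nM in this assay, at which 1 of the 4 values shown sits.

Together these steps show that this position can respond to the choice of group, which the halogen swap alone could not show, as its floor lay within the scatter. Across these three compounds, the 4-ethylphenyl form gives the lowest number, though this comparison rests on a single non-halogen group.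

The compounds shown cannot tell whether this gain comes from the size of ethyl or from some other feature of the swap, and a methyl group, a longer chain such as propyl, or an amine at the same place would help separate these possibilities. As far as these compounds go, it also remains open whether the same swap would lower the number on the core of compound 1.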